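Swapping trifluoromethyl for chloro on a shared core

A few compounds are considered here, and "the series" means these few. Any claim that something is new, unique, unknown or untested is made for them only; others in the source may bear on it.

Compound 1, `CN1CCN(CCCN(c2nc3cc(F)c(C(F)(F)F)cc3[nH]2)[C@@H]2CC[C@]3(c4ccc(C#N)cc4)C[C@H]23)CC1`, was tested in an assay on isolated protein for binding affinity to melanin-concentrating hormone receptor 1 (Homo sapiens) (on this read-out lower numbers stand for stronger inhibition and higher numbers for weaker inhibition), where compound 1 gives 8.6 nM. Two related compounds sit beside it. Compound 2, `CS(=O)(=O)N1CCC(CN(c2nc3cc(F)c(F)cc3[nH]2)[C@@H]2CC[C@]3(c4cccc(C#N)c4)C[C@@H]3C2)CC1`, gives 27 nM, and compound 3, `CS(=O)(=O)N1CCC(CN(c2nc3cc(F)c(Cl)cc3[nH]2)[C@@H]2CC[C@]3(c4cccc(C#N)c4)C[C@@H]3C2)CC1`, gives 6.7 nM. Compound 1 and compound 3 thus lie within the usual scatter of each other, while the number for compound 2 stands apart from both.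

The new compound 4, `CN1CCN(CCCN(c2nc3cc(F)c(Cl)cc3[nH]2)[C@@H]2CC[C@]3(c4ccc(C#N)cc4)C[C@H]23)CC1`, keeps everything in compound 1 except one group: chloro in place of trifluoromethyl on an aromatic carbon. Among the measured compounds shown here, no measured pair shows exactly this exchange. The nearest guide is the step of a 4.0-fold lower number from compound 2 to compound 3 (0.61 log units; beyond the scatter), which swaps a halogen at the same place on a different core, and the fact that compound 3, carrying chloro, gives 6.7 nM, close to compound 1. A trifluoromethyl-to-chloro swap is not the same as a fluoro-to-chloro swap, so that step cannot be carried over directly.

On this basis compound 4 is expected to give about 8 nM, within a range of 3 nM to 22 nM, meaning an estimated step of a 1.1-fold lower number from compound 1 to compound 4 (0.03 log units; within the scatter), well inside the scatter.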

Compound 4, inhibition constant: 4.9 nM
Beside the measured number, compound 4's estimate is 1.6-fold (0.21 log units) above it; the range from low to high includes it.
By their numbers in this assay, from the lowest: compounds 4, 3 and 1 (each within the scatter of the next); then compound 2.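

In this assay, the step of a 1.8-fold lower number from compound 1 to compound 4 (0.24 log units; within the scatter) stays within the scatter, so on this core trifluoromethyl and chloro cannot be told apart at this position. Among the compounds shown here, the earlier compounds did not show this direct exchange, only the step of a 4.0-fold lower number from compound 2 to compound 3 (0.61 log units; beyond the scatter) for chloro in place of fluoro on a different core, whereas here a group of 4 heavy atoms gives way to a single chlorine with no change that can be read. Nothing measured on the properties of these groups is available to explain this result. From the compounds shown here alone, it remains open whether a much smaller or differently built group at this place, such as a hydrogen atom, a methoxy group or an amine, would also stay within the scatter. Going by these compounds, it is also open whether trifluoromethyl and chloro would match in the same way on the core of compound 2 and compound 3.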